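The source may hold more compounds than are shown below. What is called first, only, known or untested is meant among the compounds shown, and "the series" means these compounds.

Of the compounds shown here, three sharing one core have been measured in a physicochemical assay for solubility, read by HPLC, using the shake flask method, measured as kinetic solubility, with a stated time of 2 h, at pH 7.4; on this read-out higher numbers stand for higher solubility and lower numbers for lower solubility. Compound 1 `Cc1cc(NCc2ncc[nH]2)n2nc(C)c(-c3ccccc3)c2n1` gives in this assay only a limit of the assay, < 5000 nM. Compound 2 `Cc1cc(NCc2ccccn2)n2ncc(-c3ccc(C(F)(F)F)cc3)c2n1` likewise gives a limit in this assay, < 5000 nM. Compound 3 `Cc1cc(NCc2ccccn2)n2ncc(-c3ccc(C#N)cc3)c2n1`, the starting point of the step followed here, also gives a limit in this assay, < 5000 nM. So compound 3 stands where the other two stand: at a limit of the assay rather than at a number. Among the compounds with values here, the only single-point step among the measured compounds is a step that the two limits leave unreadable from compound 2 to compound 3, and its two limits leave its size unreadable; the evidence the limit of < 5000 nM in this assay, at which 3 of the 3 values shown sit, states that every value shown rests at that same limit.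

The step from compound 3 to compound 4 `Cc1cc(NCc2ccccn2)n2ncc(-c3c(C)cccc3C)c2n1` changes (2,6-dimethylphenyl in place of 4-cyanophenyl on an aromatic carbon). Within the data shown here, no measured step bears readably on this change, since the single measured step is itself unreadable and nothing within these data separates one value from another. Compound 4 is therefore expected to sit where the measured compounds sit. The estimated step is a step that the limit leaves unreadable from compound 3 to compound 4, most likely not readable in this assay either. The estimate for compound 4 in this assay is 2000 nM, with a range from 300 nM to 8000 nM.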

Compound 4, solubility: < 5000 nM
Compound 4: only a limit was reported; the forecaster's own chance of this, stated with the estimate: 80%; the middle value lies beyond the limit too.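

In this assay, within the data shown here, compound 4, like compound 3, gives only a limit of the assay, so no step from compound 3 to compound 4 can be read. The compounds shown rest at one shared value: the limit of < 5000 nM in this assay, at which 4 of the 4 values shown sit. They leave open how far any of them lies from that limit, and whether these compounds differ at all in this assay.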